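Sulfinyl for amino on the shared core: an expected shift

The source may report more compounds than this note shows. Statements on the series, on what has been measured and on what is new or still open speak of the compounds shown alone.

Compound 3 `CCCNc1nc(N)c2nc(O)n(Cc3ccccc3)c2n1` gives 0.1 uM in a functional assay (spleen, spleen) for activation, with Mus musculus as the target (on this read-out lower numbers stand for an effect already at smaller amounts and higher numbers for an effect only at larger amounts of compound), the highest of the three numbers recorded; its nearest neighbour is compound 1 `CCCSc1nc(N)c2nc(O)n(Cc3ccccc3)c2n1`, which gives 0.01 uM. Compound 2 `CCCCSc1nc(N)c2nc(O)n(Cc3ccccc3)c2n1` gives 0.01 uM. The step of no change at the digits printed from compound 1 to compound 2 (within the scatter) shows that lengthening the chain by one carbon leaves the read-out unchanged, whereas a 10-fold higher number from compound 1 to compound 3 (1.00 log units; beyond the scatter) and a 10-fold higher number from compound 2 to compound 3 (1.00 log units; beyond the scatter) show a modest rise. Compound 4 `CCCC[S+]([O-])c1nc(N)c2nc(O)n(Cc3ccccc3)c2n1` carries a group of 6 heavy atoms (4 carbon, 1 oxygen, 1 sulfur; no ring) in place of a group of 4 heavy atoms (3 carbon, 1 nitrogen; no ring), on an aromatic carbon on an aromatic carbon. Returning sulfur to this position resembles the reverse of the step from compound 2, so a lower number is expected for compound 4, though no sulfinyl compound has been measured. Compound 4 is therefore estimated at 0.03 uM, with a range of 0.005 uM to 0.3 uM, a step of a 3.3-fold lower number from compound 3 to compound 4 (0.52 log units; beyond the scatter).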

Compound 4, minimum effective concentration: 0.01 uM
Estimate against measurement, compound 4: 3.0-fold (0.48 log units) above; the range from low to high includes it.
By their numbers in this assay, from the lowest: compounds 1, 2 and 4 (each within the scatter of the next); then compound 3.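

The sulfur position takes an added oxygen without loss in this assay: the sulfinyl group gives no change at the digits printed from compound 2 to compound 4 (within the scatter) and no change at the digits printed from compound 1 to compound 4 (within the scatter), so the earlier match between the two sulfanyl compounds now extends to an oxidised sulfur. It also gives a 10-fold lower number from compound 3 to compound 4 (1.00 log units; beyond the scatter), so the propylamino compound remains the only one of the four set apart. No evidence here accounts for this result. Open, as far as these compounds go, are the sulfone, with a second oxygen on the sulfur, and a butylamino chain at this place, which would separate chain length from the atom attached to the ring.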